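The compounds below may be only part of what the source reports. "The series", "measured", "known", "first", "only" and "open" are said of these compounds alone.

Measured compounds:
- compound 1, `O=C(NNc1nncc2ccccc12)C1CC1c1ccc(OCC(F)(F)F)cc1`: in a functional assay on OE21 cells (Homo sapiens) for inhibition, read by MTT assay, with a stated time of 72 h (on this read-out lower numbers stand for stronger inhibition and higher numbers for weaker inhibition), compound 1 gives 17000 nM
- compound 2, `CC(C)=CCC/C(C)=C/COc1ccc(C2CC2C(=O)NNc2nncc3ccccc23)cc1`: in this assay compound 2 gives 9000 nM
- compound 3, `CC(C)=CCC/C(C)=C/COc1ccc(C2CC2C(=O)NNC(=O)c2ccncc2)cc1`: in this assay compound 3 gives "not determined" (no result reported), so no single number is reported for it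

Compound 1 and compound 2 share a core and differ in one place: trifluoromethyl in place of 2,6-dimethylhepta-1,5-dien-1-yl on a saturated chain carbon bound to an oxygen on an aromatic ring. This change gave a 1.9-fold higher number from compound 2 to compound 1 (0.28 log units; within the scatter), so on the evidence of this pair the two compounds are not separated.

Compound 3 carries a different core; how it departs from compound 2 is a group of 8 heavy atoms (6 carbon, 1 nitrogen, 1 oxygen; one six-membered aromatic ring with 1 hetero atom) in place of a group of 10 heavy atoms (8 carbon, 2 nitrogen; one six-membered aromatic ring of carbon only, one six-membered aromatic ring with 2 hetero atoms), on an amine nitrogen. Compound 4, `O=C(NNC(=O)C1CC1c1ccc(OCC(F)(F)F)cc1)c1ccncc1`, is not yet measured. It differs from compound 3 by trifluoromethyl in place of 2,6-dimethylhepta-1,5-dien-1-yl on a saturated chain carbon bound to an oxygen on an aromatic ring. The place of this change in compound 3 and compound 4 reads word for word as in compound 2 and compound 1, so it is the same change, now on the other core.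

What the step from compound 3 to compound 4 will do in this assay cannot be read from compound 3, which has no number. The only anchor is the same change on the first core, where the step was a 1.9-fold higher number from compound 2 to compound 1 (0.28 log units; within the scatter), a step within the scatter; a step of similar, small size is expected here as well, though with no measured starting point the spread is wide. On that basis compound 4 is estimated at 20000 nM, with a likely range of 5000 nM to 80000 nM.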

Compound 4, half-maximal inhibitory concentration: 31000 nM
Compound 4: middle estimate off by 1.6-fold (0.19 log units), on the low side, within the range that was stated.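

In this assay compound 4 gives 31000 nM while compound 3 has no single number there, so the step between compound 3 and compound 4 cannot be read. The compounds shown leave open whether exchanging 2,6-dimethylhepta-1,5-dien-1-yl for trifluoromethyl has the same size on the core of compound 3 as on the core of compound 2. No supporting evidence bears on this result.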